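A Methoxy Added to the Phenyl Ring

This account rests on a few compounds, and the source may have more. Where it says the series, first, only, none or still open, it means among the compounds named here.

For the measured compounds named here, compound 2 `COc1cc2ncnc(Nc3cc(-c4ccccc4)[nH]n3)c2cc1OC` gives 29700 nM in a functional assay on A549 cells (Homo sapiens) for cytotoxicity, read by MTT assay (on this read-out higher numbers stand for weaker inhibition and lower numbers for stronger inhibition), the lowest of the two numbers measured so far; its nearest neighbour, compound 1 `COc1cc2ncnc(Nc3cc(O)[nH]n3)c2cc1OC`, gives 74900 nM. Going by the values given here, the only measured step, a 2.5-fold lower number from compound 1 to compound 2 (0.40 log units; beyond the scatter), concerns phenyl in place of hydroxy, a different kind of change from the one now considered. Compound 3 `COc1ccc(-c2cc(Nc3ncnc4cc(OC)c(OC)cc34)n[nH]2)cc1` differs from compound 2 by methoxy in place of hydrogen on an aromatic carbon, which one bond further out reads phenyl to 4-methoxyphenyl. Among the compounds with values here, no measured step shows how such an addition shifts this assay, so the movement expected is small and its direction uncertain. Staying close to compound 2, the estimate for compound 3 is 25000 nM, with a range from 10000 nM to 60000 nM. The step this estimate means, a 1.2-fold lower number from compound 2 to compound 3 (0.07 log units; within the scatter), is expected to remain within the scatter.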

Compound 3, half-maximal inhibitory concentration: < 100000 nM
Compound 3 ended at the assay's limit; the forecaster's own chance of this, stated with the estimate: 10%; the middle value does not contradict the limit.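

In this assay compound 3 gives < 100000 nM, which is a limit of the assay and not a number, so the steps from compound 1 and compound 2 to compound 3 cannot be read. The compounds shown leave open whether methoxy on the phenyl ring changes the number, and in which direction.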